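A Longer Link to the Cyclobutyl Ring

The source may report more compounds than this note shows. Statements on the series, on what has been measured and on what is new or still open speak of the compounds shown alone.

Measured so far:
compound 1 `CC(C)c1nc(C(=O)NCC2CCN(C3CCOCC3)CC2)c2ccccn12`: 29%
compound 2 `CC(C)c1nc(C(=O)NCC2CCN(C3CCC3)CC2)c2ccccn12`: 20%
compound 3 `CC(C)c1nc(-c2nnc(C3CCN(C4CCC4)CC3)o2)c2ccccn12`: 55%

In a functional assay on CHO cells for agonist activity at 5-hydroxytryptamine receptor 4 (Homo sapiens), read by a luciferase reporter and cAMP accumulation, with a stated time of 4 h (on this read-out lower numbers stand for smaller maximal responses and higher numbers for larger maximal responses), compound 3 stands highest of the three measured compounds; its value lies beyond the usual scatter above compound 1, and further still above compound 2. Compound 4 `CC(C)c1nc(-c2nnc(C3CCN(CC4CCC4)CC3)o2)c2ccccn12` is not yet measured. It differs from compound 3 in one place: cyclobutylmethyl in place of cyclobutyl on an amine nitrogen in a ring.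

Among the measured compounds shown here, only one measured step bears on this change, and it is a change of the group on the same amine nitrogen in a ring, though on the shared core of compounds 1 and 2 rather than on that of compound 3: a number 9 percentage points lower from compound 1 to compound 2 (within the scatter). That step did not move the maximal response beyond the scatter. The present change keeps the cyclobutyl ring and adds one carbon between it and the nitrogen, a smaller alteration than swapping ring types. The step from compound 3 to compound 4 is therefore expected to be a number 5 percentage points lower from compound 3 to compound 4 (within the scatter), with no movement beyond the scatter in either direction. Compound 4 is expected to give about 50%, within a range from 30% to 75%.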

Compound 4, largest response reached (Emax), in percent of the reference or control that the assay uses: 63%
Compound 4: the middle estimate sits 13 percentage points below what was measured; low and high end bracket the measured number.
By their numbers in this assay, from the lowest: compounds 2 and 1 (each within the scatter of the next); then compounds 3 and 4 (each within the scatter of the next).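

In this assay, cyclobutylmethyl in place of cyclobutyl on an amine nitrogen in a ring gives a number 8 percentage points higher from compound 3 to compound 4 (within the scatter) on the core of compound 3, so the added carbon does not move the maximal response beyond the usual scatter. The earlier step at this nitrogen swapped one ring for another on a different core, whereas this one keeps the ring and shows that, on this core, the cyclobutyl ring need not be bonded to the nitrogen itself for the response to hold. Nothing measured here accounts for this result.

From the compounds shown here alone, it remains open whether a longer chain such as cyclobutylethyl, or oxan-4-ylmethyl, would also hold the response on this core. The compounds shown also do not tell whether cyclobutylmethyl would behave the same way on the shared core of compounds 1 and 2.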